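Removing the trifluoromethyl: from compound 2 to compound 3

This account rests on a few compounds, and the source may have more. Where it says the series, first, only, none or still open, it means among the compounds named here.

compound 1 `CCOC(=O)/C(=C/c1ccccc1)CN1C(=O)[C@@H](OC)[C@H]1c1cccc([N+](=O)[O-])c1`: 19900 nM
compound 2 `COC(=O)/C(=C/c1ccccc1)CN1C(=O)[C@@H](OC)[C@H]1c1cccc(C(F)(F)F)c1`: no result reported

Going by the values given here, in a functional assay on MCF7 cells (Homo sapiens) for antiproliferative activity, read by MTT assay, with a stated time of 48 h (on this read-out lower numbers stand for stronger inhibition and higher numbers for weaker inhibition), compound 1 gives 19900 nM, the only number in this set. In this assay compound 2 gives no result reported, so its standing cannot be placed on a measured number; it shares the core of compound 1 but carries a trifluoromethyl in place of the nitro and a methyl ester in place of the ethyl ester. Compound 3 `COC(=O)/C(=C/c1ccccc1)CN1C(=O)[C@@H](OC)[C@H]1c1ccccc1` is the next step: hydrogen in place of trifluoromethyl on an aromatic carbon. Among the compounds with values here, with no pair of measured compounds to set a scale, the expected size of this step is small, and the direction is uncertain; a change within the scatter of this assay is as likely as a move either way. On that basis compound 3 is expected to give about 25000 nM in this assay, with a range from 8000 nM to 80000 nM.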

Compound 3, half-maximal inhibitory concentration: 12900 nM
Compound 3: middle estimate off by 1.9-fold (0.29 log units), on the high side; the measured number falls inside the stated range.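

With no number shown for compound 2, the step to compound 3 cannot be read, and compound 1 differs from compound 3 in more than one place. The compounds shown leave open what trifluoromethyl, nitro or the ester each contribute in this assay on their own. No supporting evidence bears on this result.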